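Adding a second bromo to the benzamide ring

The source may hold more compounds than are shown below. What is called first, only, known or untested is meant among the compounds shown, and "the series" means these compounds.

Compound 1 `O=C(Nc1ccc(Sc2nc3ccccc3s2)c(Cl)c1)c1cccc(Br)c1`: > 100000 nM
Compound 2 `O=C(Nc1ccc(Sc2nc3ccccc3s2)cc1)c1cccc(Br)c1`: 74000 nM
Compound 3 `COc1c(Br)cc(Br)cc1C(=O)Nc1cccc(Cl)c1`: > 100000 nM

In an ADME assay on HEK293 cells (Homo sapiens) for cytotoxicity, read by reporter gene assay and resazurin assay, with a stated time of 48 h (a higher number here means that more compound is tolerated, a lower number that less compound is tolerated), compound 1 reaches only the limit of > 100000 nM, a limit and not a number. Compound 3 likewise sits at the limit of > 100000 nM. Among the compounds with values here, compound 2 gives 74000 nM, the one measured number in the set. Within the data shown here, the other two values are limits, so compound 2 stands as the only compound with a read number, and two of three values sit at the limit (the limit of > 100000 nM in this assay, at which 2 of the 3 values shown sit).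

Among the measured compounds shown here, the one measured step is an at least 1.3-fold lower number from compound 1 to compound 2 (0.13 log units; that floor lies within the scatter), a change on the aniline ring, not on the benzamide ring. It stays within the scatter. Compound 4 `O=C(Nc1ccc(Sc2nc3ccccc3s2)cc1)c1cc(Br)cc(Br)c1` differs from compound 2 by bromo in place of hydrogen on an aromatic carbon, giving 3,5-dibromophenyl in place of 3-bromophenyl. For the measured compounds named here, no measured step touches that ring, so the step from compound 1 to compound 2 bears on it only as a sign that small halogen changes here have not moved this assay beyond the scatter.

Compound 4 is therefore expected to show a 1.1-fold higher number from compound 2 to compound 4 (0.03 log units; within the scatter), no change beyond the scatter. Compound 4 is estimated at 80000 nM, within 35000 nM to 200000 nM, with a fair chance that only a limit is reported.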

Compound 4, half-maximal cytotoxic concentration: > 100000 nM
Compound 4 gave a limit, no number; the forecaster's own chance of this, stated with the estimate: 40%; at least 1.2-fold (0.09 log units) between middle value and limit.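

In this assay, the second bromo, which turns 3-bromophenyl into 3,5-dibromophenyl, gives the only step on the benzamide ring among the compounds shown, and it reads as an at least 1.3-fold higher number from compound 2 to compound 4 (0.13 log units; that floor lies within the scatter). Compound 4 gives > 100000 nM, which is a limit and not a number. At this position, on an aromatic carbon meta to a bromo group, the added bromo therefore brings no drop in the tolerated concentration, something the earlier step on the aniline ring could not show, but only a floor within the scatter can be read and the true size of the step stays unknown because the value of compound 4 rests on the ceiling of the assay: the limit of > 100000 nM in this assay, at which 3 of the 4 values shown sit.

The compounds shown leave open how far compound 4 lies past that limit, and so whether the second bromo changes the read-out at all. They also leave open whether this carbon would stay as well tolerated if it carried an amine or a carboxylic acid instead of a halogen.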